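Replacing the Pyridin-2-yl Ring with an Open Chain

This account rests on a few compounds, and the source may have more. Where it says the series, first, only, none or still open, it means among the compounds named here.

Measured so far in a functional assay for activation of Alpha-1A adrenergic receptor (Homo sapiens), read by calcium flux; a lower number here means that less compound is needed, a higher number that more compound is needed for the effect:
compound 1, `Cc1cc(-c2ccccc2NCC2=NCCN2)on1`, gives 38.9 nM
compound 2, `Cc1ccc(-c2ccccc2NCC2=NCCN2)o1`, gives 2.69 nM
compound 3, `c1ccc(-c2ccccc2NCC2=NCCN2)nc1`, gives 6.76 nM

Compound 3 sits in the middle of these three: in this assay compound 3 needs less compound than compound 1, with a 5.8-fold lower number from compound 1 to compound 3 (0.76 log units; beyond the scatter), and more than compound 2, with a 2.5-fold higher number from compound 2 to compound 3 (0.40 log units; beyond the scatter). Both gaps are beyond the scatter.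

Compound 4, `CCO/N=C(\C)c1ccccc1NCC1=NCCN1`, is made from compound 3 by a change at one place: a group of 6 heavy atoms (4 carbon, 1 nitrogen, 1 oxygen; no ring) in place of a group of 6 heavy atoms (5 carbon, 1 nitrogen; one six-membered aromatic ring with 1 hetero atom), on an aromatic carbon. All three measured steps change the same position, but each swaps one aromatic ring for another; none opens the ring into a chain. What they do show is that this position tolerates exchange without losing activity outright, with steps ranging from a 2.5-fold higher number from compound 2 to compound 3 (0.40 log units; beyond the scatter) to a 14-fold lower number from compound 1 to compound 2 (1.16 log units; beyond the scatter). For the measured compounds named here, since the open chain has no precedent among the measured compounds, the direction of the step is uncertain; a modest change, either way, seems more likely than a large one.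

The estimate for compound 4 in this assay is therefore 15 nM, within a range from 3 nM to 80 nM, corresponding to an expected step of a 2.2-fold higher number from compound 3 to compound 4 (0.35 log units; beyond the scatter).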

Compound 4, half-maximal effective concentration: 52.5 nM
Estimate against measurement, compound 4: 3.5-fold (0.54 log units) below, and the stated range covers the measured number.
By their numbers in this assay, from the lowest: compound 2; then compound 3; then compounds 1 and 4 (each within the scatter of the next).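

For the compounds shown here, the open chain is the first group without a ring at this position, and it still gives a measurable effect in this assay, so a ring on this aromatic carbon is not required for activation. The chain does come at a cost against two of the rings (a 7.8-fold higher number from compound 3 to compound 4 (0.89 log units; beyond the scatter)) (a 20-fold higher number from compound 2 to compound 4 (1.29 log units; beyond the scatter)), showing that the pyridin-2-yl and 5-methylfuran-2-yl rings each give a lower number than this chain. Against the 3-methyl-1,2-oxazol-5-yl ring there is no such cost (a 1.3-fold higher number from compound 1 to compound 4 (0.13 log units; within the scatter)), so having a ring is not enough on its own to give a low number here.

Still open, as far as these compounds go, is how a simple amine, a carboxylic acid or a longer carbon chain on this aromatic carbon would behave, and whether any open chain can reach the numbers of the better rings. Also open is why the chain falls short of those two rings, since nothing measured here bears on that question.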